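The source may hold more compounds than are shown below. What is called first, only, known or untested is meant among the compounds shown, and "the series" means these compounds.

In a functional assay on HT-29 cells (Homo sapiens) for inhibition, read by CCK-8 assay, with a stated time of 24 h (on this read-out lower numbers stand for stronger inhibition and higher numbers for weaker inhibition), compound 1 `O=C1Nc2ccccc2/C1=C/c1ccc(-c2cn(-c3ccccc3F)nn2)cc1` gives 10500 nM and compound 2 `Cc1ccc(-n2cc(-c3ccc(/C=C4\C(=O)Nc5ccc(F)cc54)cc3)nn2)cc1` gives 3980 nM. Compound 2 thus holds the lower of the two numbers, by a gap beyond the usual scatter. Compound 3 `O=C1Nc2ccc(F)cc2/C1=C/c1ccc(-c2cn(-c3ccccc3F)nn2)cc1` differs from compound 2 by 2-fluorophenyl in place of 4-methylphenyl on an aromatic nitrogen. Compound 1, which also carries 2-fluorophenyl, gives 10500 nM, so a small shift toward weaker inhibition in this assay is expected, perhaps no larger than the scatter. The expected step is a 1.4-fold higher number from compound 2 to compound 3 (0.14 log units; within the scatter). Compound 3 is estimated at 5500 nM, within a range of 2200 nM to 12000 nM.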

Compound 3, half-maximal inhibitory concentration: 8980 nM
Estimate against measurement, compound 3: 1.6-fold (0.21 log units) below; measured number inside the range.
By their numbers in this assay, from the lowest: compound 2; then compounds 3 and 1 (each within the scatter of the next).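

In this assay, going by these compounds alone, 2-fluorophenyl in place of 4-methylphenyl on the aromatic nitrogen gives a 2.3-fold higher number from compound 2 to compound 3 (0.35 log units; beyond the scatter), the first reading of this position with the rest of the molecule held fixed. Fluoro in place of hydrogen on an aromatic carbon gives a 1.2-fold lower number from compound 1 to compound 3 (0.07 log units; within the scatter), so in this pair the ring fluorine leaves the number unchanged. No evidence at hand explains either step. The compounds shown leave open how an amine or a carboxylic acid on this phenyl ring would read, and whether a longer chain could stand in its place on the nitrogen.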